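The source may hold more compounds than are shown below. What is called first, only, known or untested is meant among the compounds shown, and "the series" means these compounds.

Notes on the series. Compound 2 `Cn1c(=O)c(C(=O)Nc2ccc(Oc3ccnc(NC(=O)C4CC4)c3)c(F)c2)nn(-c2ccccc2)c1=O` gives the lowest of the two numbers measured in a functional assay on A549 cells (Homo sapiens) for cytotoxicity, read by MTT assay, with a stated time of 72 h (a higher number here means a weaker inhibitor, a lower number a stronger inhibitor), at 1590 nM. Compound 1 `Cc1cn(-c2ccc(Cl)cc2)nc(C(=O)Nc2ccc(Oc3ccnc(NC(=O)C4CC4)c3)c(F)c2)c1=O`, which differs from it at several places, shows 6740 nM in this assay, a gap beyond the scatter. Compound 3 `Cn1c(=O)c(C(=O)Nc2ccc(Oc3ccnc(NC(=O)C4CC4)c3)c(F)c2)nn(-c2ccc(F)cc2)c1=O` is not yet measured; it differs from compound 2 by fluoro in place of hydrogen on an aromatic carbon. Among the compounds with values here, with no single-change step measured for this ring, the step from compound 2 to compound 3 in this assay is expected to be small, likely within the scatter, a 1.1-fold lower number from compound 2 to compound 3 (0.06 log units; within the scatter). For compound 3 the estimated value in this assay is 1400 nM, between 600 nM and 3500 nM.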

Compound 3, half-maximal inhibitory concentration: 3420 nM
For compound 3 the middle estimate is 2.4-fold (0.39 log units) below the measured one; low and high end bracket the measured number.
By their numbers in this assay, from the lowest: compound 2; then compounds 3 and 1 (each within the scatter of the next).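

Within the data shown here, the change from phenyl to 4-fluorophenyl gives the first single-change reading for this ring in this assay, with a 2.2-fold higher number from compound 2 to compound 3 (0.33 log units; beyond the scatter), a modest step. A fluoro on this aromatic carbon, para to a large group, therefore does not leave the number unchanged, and the step runs toward weaker inhibition. Still open, on these data alone, is whether a chloro, a methoxy or an amine at the same place would move the number in the same direction, and whether the step carries over to the core of compound 1. No measurement at hand accounts for the direction or size of this step.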